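The compounds below may be only part of what the source reports. "The series", "measured", "known", "first", "only" and "open" are said of these compounds alone.

Measured compounds:
compound 1, `O=C(CCCCC1CCSS1)Nc1ccc(Cl)cn1`, 27.5%
compound 2, `O=C(CCCCC1CCSS1)Nc1cccc2ccccc12`, "not active" (no number reported)
compound 3, `O=C(CCCCC(S)CCS)Nc1ccc(Cl)cn1`, 21.9%

In a functional assay on HO8910 cells (Homo sapiens) for inhibition, read by MTT assay, with a stated time of 24 h, tested at 10 ug/mL (a higher number here means more inhibition of growth at the concentration tested, a lower number less inhibition of growth), compound 1 gives 27.5%, and compound 3 gives 21.9%. The step between them is a number 5.6 percentage points lower from compound 1 to compound 3 (within the scatter), the change being (a group of 5 heavy atoms (3 carbon, 2 sulfur; no ring) in place of a group of 5 heavy atoms (3 carbon, 2 sulfur; one five-membered non-aromatic ring with 2 hetero atoms), on a saturated chain carbon, four bonds along the chain from a carbonyl carbon). Compound 2 is reported in this assay only as "not active" (no number reported), with no number attached. The difference between the core of compound 1 and the core of compound 2 is not broken down here.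

Compound 4, `O=C(CCCCC(S)CCS)Nc1cccc2ccccc12`, has not yet been tested. It differs from compound 2 by a group of 5 heavy atoms (3 carbon, 2 sulfur; no ring) in place of a group of 5 heavy atoms (3 carbon, 2 sulfur; one five-membered non-aromatic ring with 2 hetero atoms), on a saturated chain carbon, four bonds along the chain from a carbonyl carbon, the same kind of change as that from compound 1 to compound 3. Since that earlier step, a number 5.6 percentage points lower from compound 1 to compound 3 (within the scatter), stayed within the scatter, and compound 2 showed no activity, compound 4 is expected to show little inhibition as well, at about 10%, estimated between 0% and 25%.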

Compound 4, percent growth inhibition at one concentration: "not active" (no number reported)
Compound 4: no number reported; there is nothing to compare the estimate with.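

In this assay compound 2 gives "not active" (no number reported) and compound 4 gives "not active" (no number reported) with no number for either, so no step can be read between them. As far as these compounds go, what the 1,3-disulfanylpropyl group does on the core of compound 2 stays open. Nothing available here bears on a reason for this result.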